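A few compounds are considered here, and "the series" means these few. Any claim that something is new, unique, unknown or untested is made for them only; others in the source may bear on it.

Working notes on the oxindole-piperazine set.

Three compounds have numbers in an assay on membranes from frontal cortex for displacement of a labelled ligand from Adrenergic receptor alpha-1 (Rattus norvegicus), read by scintillation counting, with a stated time of 45 min; a higher number here means a weaker inhibitor, a lower number a stronger inhibitor. Compound 1 `CCC1(CCCCN2CCN(c3ccc(F)cc3)CC2)C(=O)Nc2ccccc21` gives 39 nM. Compound 2 `O=C1Nc2ccccc2C1CCCCN1CCN(c2cccc(Cl)c2)CC1` gives 26 nM. Compound 3 `O=C1Nc2cc(F)ccc2C1CCCCN1CCN(c2cccc(Cl)c2)CC1` gives 12.5 nM. Within the data shown here, compound 2 stands second highest of the three; the gap to compound 1 lies within the scatter, while the step of a 2.1-fold lower number from compound 2 to compound 3 (0.32 log units; beyond the scatter) is beyond it and is the only single-point step that can be counted in this set.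

Compound 4 `O=C1Nc2ccccc2C1CCCCN1CCN(c2ccc(F)cc2)CC1` is not yet measured. It differs from compound 2 in one place: 4-fluorophenyl in place of 3-chlorophenyl on an amine nitrogen in a ring. Among the measured compounds shown here, no measured step touches the aryl group on the piperazine; the step from compound 2 to compound 3 concerns the shared core and does not bear on this change. Compound 1 does carry the 4-fluorophenyl, but it also differs from compound 2 on the core, so only the two values themselves can be read, and they sit within the scatter of each other.

The expectation for compound 4 is therefore no step beyond the scatter, with a 1.3-fold higher number from compound 2 to compound 4 (0.13 log units; within the scatter) as the estimated step. Compound 4 is expected to give 35 nM, in the range 15 nM to 80 nM.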

Compound 4, inhibition constant: 14 nM
Compound 4: middle estimate off by 2.5-fold (0.40 log units), on the high side, and the stated range ends above it.
By their numbers in this assay, from the lowest: compounds 3, 4, 2 and 1 (each within the scatter of the next, the first and the last beyond it).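

In this assay, 4-fluorophenyl in place of 3-chlorophenyl on an amine nitrogen in a ring gives a 1.9-fold lower number from compound 2 to compound 4 (0.27 log units; within the scatter) and thus shows that this pair of aryl groups cannot be told apart at this position. Compound 4 also isolates a change on the core that compounds 1 and 2 could not, since they differ in two places: hydrogen in place of ethyl on a saturated ring carbon gives a 2.8-fold lower number from compound 1 to compound 4 (0.44 log units; beyond the scatter) as a modest step with the 4-fluorophenyl held constant. No measurement at hand accounts for either step.

Open, as far as these compounds go, is whether a plain phenyl, a methoxyphenyl or a pyridyl on that nitrogen stays within the scatter of these two aryl groups. Also open, from the compounds shown here alone, is how methyl or a longer chain in place of the ethyl would read.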